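Amine tail variation on the urea chain: compound 4

A few compounds are considered here, and "the series" means these few. Any claim that something is new, unique, unknown or untested is made for them only; others in the source may bear on it.

Measured compounds:
compound 1, `COc1ncc(-c2ccc3nc(NC(=O)NCCN(C)C)sc3c2)cc1NS(=O)(=O)c1ccc(F)cc1`, in a functional assay on A549 cells (Homo sapiens) for antiproliferative activity, read by MTT assay, with a stated time of 72 h (on this read-out higher numbers stand for weaker inhibition and lower numbers for stronger inhibition), gives 470 nM
compound 2, `CCN(CC)CCNC(=O)Nc1nc2ccc(-c3cnc(OC)c(NS(=O)(=O)c4ccc(F)cc4)c3)cc2s1`, in this assay gives 450 nM
compound 3, `CCN(CC)CCNC(=O)Nc1nc2ccc(-c3cnc(OC)c(NS(=O)(=O)c4ccc(C)cc4)c3)cc2s1`, in this assay gives 310 nM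

Compound 2 stands second highest of the three numbers; its nearest neighbour is compound 1, and compound 3 lies furthest, with both gaps inside the scatter. The step from compound 2 to the unmeasured compound 4, `COc1ncc(-c2ccc3nc(NC(=O)NCCN4CCCCC4)sc3c2)cc1NS(=O)(=O)c1ccc(F)cc1`, is piperidin-1-yl in place of diethylamino on a saturated chain carbon, two bonds along the chain from an amide-type nitrogen.

Within the data shown here, only one measured step touches the same place: a 1.0-fold lower number from compound 1 to compound 2 (0.02 log units; within the scatter). That exchange of one dialkylamino tail for another left the number essentially unchanged. The other step, a 1.5-fold lower number from compound 2 to compound 3 (0.16 log units; within the scatter), sits elsewhere on the molecule and is also within the scatter. Nothing here suggests that the amine tail on this chain moves the read-out, so for compound 4 no step beyond the scatter is expected in either direction; the estimated step is a 1.1-fold lower number from compound 2 to compound 4 (0.03 log units; within the scatter). Compound 4 is accordingly expected to give 420 nM, with a range from 200 nM to 900 nM.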

Compound 4, half-maximal inhibitory concentration: 330 nM
The estimate for compound 4 lay 1.3-fold (0.10 log units) above the measured number; low and high end bracket the measured number.
By their numbers in this assay, from the lowest: compounds 3, 4, 2 and 1 (each within the scatter of the next).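

In this assay, piperidin-1-yl on a saturated chain carbon, two bonds along the chain from an amide-type nitrogen, gives a 1.4-fold lower number from compound 2 to compound 4 (0.13 log units; within the scatter) against diethylamino and a 1.4-fold lower number from compound 1 to compound 4 (0.15 log units; within the scatter) against dimethylamino and so extends the comparison from open dialkylamino tails to a six-membered non-aromatic ring. Closing the tail into this ring therefore leaves compound 4 within the scatter of both compound 1 and compound 2, and these three tails cannot be told apart on this read-out. No supporting data bear on why the three tails read alike.

From the compounds shown here alone, whether a morpholin-4-yl or 4-methylpiperazin-1-yl tail, a longer chain carrying the amine, or a carboxylic acid in place of the amine would separate from these three remains open. Also open, going by these compounds, is how methyl in place of fluoro on the aromatic carbon reads with the piperidin-1-yl tail of compound 4.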